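A few compounds are considered here, and "the series" means these few. Any claim that something is new, unique, unknown or untested is made for them only; others in the source may bear on it.

Measured compounds in an assay for inhibition of Tryptophan 2,3-dioxygenase (Homo sapiens), with stated times of 10 min and 60 min, tested at 10 uM; on this read-out higher numbers stand for a stronger effect at the one concentration tested and lower numbers for a weaker effect:
- compound 1 `O=[N+]([O-])c1ccccc1CNc1cc(C(F)(F)F)cc2[nH]ncc12`: 89%
- compound 2 `O=[N+]([O-])c1ccccc1CNc1cc(Br)cc2[nH]ncc12`: 52%
- compound 3 `N#Cc1cc(NCc2ccccc2[N+](=O)[O-])c2cn[nH]c2c1`: 22%

On these numbers compound 3 stands lowest of the three. Its nearest neighbour is compound 2, a number 30 percentage points lower from compound 2 to compound 3 (beyond the scatter). The furthest is compound 1, a number 67 percentage points lower from compound 1 to compound 3 (beyond the scatter). Both steps exceed the usual scatter, so the group on this aromatic carbon of the shared core clearly matters to the read-out in this assay.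

Compound 4 `O=[N+]([O-])c1ccccc1CNc1cccc2[nH]ncc12` is the next member, not yet measured. Its difference from compound 3: hydrogen in place of cyano on an aromatic carbon.

Within the data shown here, no measured step removes a group from this position outright; the three steps on hand (a number 37 percentage points lower from compound 1 to compound 2 (beyond the scatter), a number 67 percentage points lower from compound 1 to compound 3 (beyond the scatter), a number 30 percentage points lower from compound 2 to compound 3 (beyond the scatter)) all exchange one substituent for another, and each of the two that end at the cyano compound is a fall. Cyano is the weakest of the three groups tried, and hydrogen has no comparator within the series. The step from compound 3 to compound 4 is therefore expected to be small, at or below the scatter, with the read-out in this assay staying low; the expected step is a number 7 percentage points lower from compound 3 to compound 4 (within the scatter).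

For compound 4 the expected value in this assay is 15%, with a range from 0% to 40%.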

Compound 4, a percentage reported as inhibition, at one concentration (the size of the read-out at that concentration, not a potency): 45%
Estimate against measurement, compound 4: 30 percentage points below, and the stated range ends below it.
By their numbers in this assay, from the lowest: compound 3; then compounds 4 and 2 (each within the scatter of the next); then compound 1.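

In this assay, compound 4 supplies the missing reference for this aromatic carbon, and the series no longer reads as a simple ranking of three substituents: taking away the nitrile gives a number 23 percentage points higher from compound 3 to compound 4 (beyond the scatter). Exchanging bromo for hydrogen gives a number 7 percentage points lower from compound 2 to compound 4 (within the scatter), so these two compounds cannot be told apart and bromo shows no gain over an open position, whereas exchanging trifluoromethyl for hydrogen gives a number 44 percentage points lower from compound 1 to compound 4 (beyond the scatter). Set against hydrogen, only trifluoromethyl stands clear above and only cyano clear below, so a group on this carbon is not needed for a read-out at the level of compound 4, and the read-out of compound 3 is tied to the nitrile rather than being the level of the core itself; nothing on hand gives a reason for these differences.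

Open, going by these compounds, is how other groups on this carbon would fall against hydrogen and trifluoromethyl, for example methyl, chloro, methoxy, an amine or a carboxylic acid. Also open, on these data alone, is whether the same ranking would hold with an amine in place of the nitro group, or at other concentrations, as each number here is a read-out at one concentration and not a potency.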